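This account rests on a few compounds, and the source may have more. Where it says the series, first, only, none or still open, it means among the compounds named here.

- compound 1 `Cc1ccc(N(C(=O)c2cccc([N+](=O)[O-])c2)C(=S)OCCN2C(=O)c3ccccc3C2=O)cc1` gives 100000 nM here
- compound 2 `Cc1ccc(N(C(=O)c2ccc(Cl)c(Cl)c2)C(=S)OCCN2C(=O)c3ccccc3C2=O)cc1` gives 17000 nM here
- compound 3 `Cc1ccc(N(C(=O)c2ccc([N+](=O)[O-])cc2Cl)C(=S)OCCN2C(=O)c3ccccc3C2=O)cc1` awaits measurement

For the measured compounds named here, compound 2 stands lowest of the two numbers so far in an ADME assay on MT4 cells (Homo sapiens) for cytotoxicity, read by MTT assay (a lower number here means that less compound is tolerated, a higher number that more compound is tolerated), at 17000 nM and its nearest neighbour is compound 1. The move to compound 3 is 2-chloro-4-nitrophenyl in place of 3,4-dichlorophenyl on a carbonyl carbon. Going by the values given here, one measured step bears on this, at the same carbonyl carbon: a 5.9-fold lower number from compound 1 to compound 2 (0.77 log units; beyond the scatter) (modest). Compound 3 keeps a nitro substituent like compound 1 at 100000 nM and one chlorine like compound 2 at 17000 nM so a number inside that span is expected, on thin evidence. In this assay the expected step is a 2.4-fold higher number from compound 2 to compound 3 (0.37 log units; beyond the scatter) (upward, modest). The estimate for compound 3 is 40000 nM (expected range 14000 nM to 100000 nM).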

Compound 3, half-maximal cytotoxic concentration: 17000 nM
Estimate against measurement, compound 3: 2.4-fold (0.37 log units) above; the range from low to high includes it.
By their numbers in this assay, from the lowest: compounds 2 and 3 (each within the scatter of the next); then compound 1.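

In this assay, a nitro group on the ring at this carbonyl carbon does not by itself keep the number high: with 2-chloro-4-nitrophenyl in place of 3,4-dichlorophenyl, the result is no change at the digits printed from compound 2 to compound 3 (within the scatter). Replacing 3-nitrophenyl with 2-chloro-4-nitrophenyl gives a 5.9-fold lower number from compound 1 to compound 3 (0.77 log units; beyond the scatter), so among these three compounds the two rings carrying chlorine stand together and the ring without chlorine stands apart, with no compound against this, though the nitro group also changes place in that step. No available evidence explains this grouping.

These compounds do not separate the contribution of the chlorine from that of the nitro group's placement. An unsubstituted phenyl, a 4-chlorophenyl or a ring bearing an amine at this carbonyl carbon would test whether the grouping holds.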